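This account rests on a few compounds, and the source may have more. Where it says the series, first, only, none or still open, it means among the compounds named here.

Of the compounds shown here, three on a shared core have been tested in a functional assay on MCF7 cells (Homo sapiens) for antiproliferative activity, read by MTT assay, with a stated time of 48 h; a lower number here means a stronger inhibitor, a higher number a weaker inhibitor. Compound 1 `N#CC1=C(N)Oc2c(c3nc4ccccc4nc3c3ccccc23)C12C(=O)N(Cc1cnnn1-c1ccc(S(N)(=O)=O)cc1)c1ccccc12` gives > 50000 nM, which is a limit of the assay and not a number. Compound 2 `Cc1ccc(-n2nncc2CN2C(=O)C3(C(C#N)=C(N)Oc4c3c3nc5ccccc5nc3c3ccccc43)c3ccccc32)cc1C` gives > 50000 nM, again a limit. The step that the two limits leave unreadable from compound 1 to compound 2 is thus unreadable. Compound 3 `N#CC1=C(N)Oc2c(N)cc3nc4ccccc4nc3c2C12C(=O)N(Cc1cnnn1-c1ccc([N+](=O)[O-])cc1)c1ccccc12` gives > 50000 nM, also a limit, so all three values sit at the limit of > 50000 nM in this assay, at which 3 of the 3 values shown sit. Compound 4 `N#CC1=C(N)Oc2c(N)cc3nc4ccccc4nc3c2C12C(=O)N(Cc1cnnn1-c1ccc(F)c(Cl)c1)c1ccccc12` differs from compound 3 in one place: 3-chloro-4-fluorophenyl in place of 4-nitrophenyl on an aromatic nitrogen. Among the compounds with values here, no measured step bears on this change, as the only available step is unreadable. Compound 4 is therefore expected to remain near the limit, with an estimated value of 80000 nM, between 30000 nM and 300000 nM. The expected step that the limit leaves unreadable from compound 3 to compound 4 means no change beyond the scatter.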

Compound 4, half-maximal inhibitory concentration: 17800 nM
Compound 4: the middle estimate sits 4.5-fold (0.65 log units) above what was measured; measured number below the stated range.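

In this assay, replacing 4-nitrophenyl with 3-chloro-4-fluorophenyl on the aromatic nitrogen gives an at least 2.8-fold lower number from compound 3 to compound 4 (0.44 log units; beyond the scatter), so a change at this position can bring a compound within the measurable range, which the unreadable step between compound 1 and compound 2 could not show. Going by these compounds, the value of compound 3, > 50000 nM, is a limit and not a number, so the true size of the step is unknown. Most values shown still sit at the ceiling: the limit of > 50000 nM in this assay, at which 3 of the 4 values shown sit.

On these data alone, it remains open whether the chlorine, the fluorine or both account for the change. As far as these compounds go, the effect of an amine or a carboxylic acid on that phenyl ring also remains open.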